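A few compounds are considered here, and "the series" means these few. Any claim that something is new, unique, unknown or untested is made for them only; others in the source may bear on it.

Measured so far:
compound 2 `O=C(O)c1ccccc1-c1ccc(CCc2ncc(Cc3ccccc3F)[nH]2)cc1`: 177 nM
compound 3 `O=C(O)c1ccccc1-c1ccc(CCc2ncc(Cc3ccc(Cl)cc3)[nH]2)cc1`: 2290 nM
compound 1 `CCCCc1cnc(Cc2ccc(-c3ccccc3C(=O)O)cc2)[nH]1`: a limit only, > 10000 nM

In an in vitro functional assay on cells for agonist activity at Bombesin receptor subtype-3 (Homo sapiens), read by luminescence and calcium flux (a lower number here means that less compound is needed, a higher number that more compound is needed for the effect), compound 3 stands highest of the two numbers; its nearest neighbour is compound 2, and the measured step of a 13-fold higher number from compound 2 to compound 3 (1.11 log units; beyond the scatter). Compound 1 reaches only the assay limit, (the limit of > 10000 nM in this assay, at which 1 of the 3 values shown sits). Compound 4 `CC(C)(C)c1cnc(CCc2ccc(-c3ccccc3C(=O)O)cc2)[nH]1` is not yet measured; it differs from compound 3 by tert-butyl in place of 4-chlorobenzyl on an aromatic carbon. Within the data shown here, the only measured step with a bearing is a 13-fold higher number from compound 2 to compound 3 (1.11 log units; beyond the scatter), which shows a large sensitivity to the group on this ring carbon; compound 1 returns only a limit in this assay. A further rise beyond the scatter is therefore expected, a 3.5-fold higher number from compound 3 to compound 4 (0.54 log units; beyond the scatter). Compound 4 is estimated at 8000 nM, range 2000 nM to 30000 nM, with a fair chance that only a limit is reported.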

Compound 4, half-maximal effective concentration: 4330 nM
Estimate against measurement, compound 4: 1.8-fold (0.27 log units) above; low and high end bracket the measured number.
By their numbers in this assay, from the lowest: compound 2; then compounds 3 and 4 (each within the scatter of the next). At a limit, above all of these: compound 1.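

Tert-butyl in place of 4-chlorobenzyl gives a 1.9-fold higher number from compound 3 to compound 4 (0.28 log units; within the scatter) in this assay, so a six-membered aromatic ring on this aromatic carbon is not needed to hold that level. Against 2-fluorobenzyl, the same group gives a 24-fold higher number from compound 2 to compound 4 (1.39 log units; beyond the scatter), so among these compounds only 2-fluorobenzyl stands apart at this position. Nothing shown gives a cause for either step. Open, as far as these compounds go, is whether the fluorine itself carries the lower number of compound 2, which plain benzyl would test. Also open, from the compounds shown here alone, is how this position takes a group of another kind, such as aminomethyl or a longer alkyl chain.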